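Acyl variation at the ring amide: compound 3 to compound 4

The compounds below may be only part of what the source reports. "The series", "measured", "known", "first", "only" and "open" are said of these compounds alone.

Measured so far in an assay on IM-9 cells for displacement of a labelled ligand from Substance-P receptor (Homo sapiens), read by scintillation counting, with a stated time of 30 min; a lower number here means a stronger inhibitor, a higher number a weaker inhibitor:
compound 1, `CC(=O)N1CC[C@@H](C(=O)N(C)Cc2cc(C(F)(F)F)cc(C(F)(F)F)c2)[C@H](c2ccccc2)C1`, gives 2.6 nM;
compound 2, `CC(=O)N1CC[C@H](C(=O)N(C)Cc2cc(C(F)(F)F)cc(C(F)(F)F)c2)[C@H](c2ccccc2)C1`, gives 3.2 nM;
compound 3, `CC(=O)NCC(=O)N1CC[C@@H](C(=O)N(C)Cc2cc(C(F)(F)F)cc(C(F)(F)F)c2)[C@H](c2ccccc2)C1`, gives 12 nM.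

Compound 3 holds the highest number of the three. Within the data shown here, the step of a 4.6-fold higher number from compound 1 to compound 3 (0.66 log units; beyond the scatter) is the only one that changes the acyl group on the ring nitrogen, and it cost potency. The step of a 1.2-fold higher number from compound 1 to compound 2 (0.09 log units; within the scatter) rests on the fact that compounds 1 and 2 differ only in the configuration as drawn and is not a change in substitution.

Compound 4, `CC(=O)N1CCC(C(=O)N2CC[C@@H](C(=O)N(C)Cc3cc(C(F)(F)F)cc(C(F)(F)F)c3)[C@H](c3ccccc3)C2)CC1`, takes the series on from compound 3 by 1-acetylpiperidin-4-yl in place of acetamidomethyl on a carbonyl carbon. Among the measured compounds shown here, no measured pair covers this exchange; the acetamidomethyl group itself is what compound 3 added to compound 1, so the step from compound 1 to compound 3 is the closest guide, and it shows that the acyl group on the ring nitrogen is tolerated with modest loss. Replacing that group with 1-acetylpiperidin-4-yl removes the hydrogen-bond donor that entered in compound 3 and brings a ring in its place. With nothing in the measured steps pointing either way, a step of about a 1.2-fold lower number from compound 3 to compound 4 (0.08 log units; within the scatter) in this assay is expected, close to compound 3. Compound 4 is estimated at 10 nM, with a range from 3 nM to 35 nM.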

Compound 4, half-maximal inhibitory concentration: 0.098 nM
The estimate for compound 4 lay 100-fold (2.01 log units) above the measured number; the measured number lies below the stated range.
By their numbers in this assay, from the lowest: compound 4; then compounds 1 and 2 (each within the scatter of the next); then compound 3.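

Among these compounds, at the carbonyl carbon bound to the ring amide nitrogen, the acyl group is more than a tolerated appendage: in this assay, the only earlier change here was a loss, a 4.6-fold higher number from compound 1 to compound 3 (0.66 log units; beyond the scatter), whereas 1-acetylpiperidin-4-yl gives a 120-fold lower number from compound 3 to compound 4 (2.09 log units; beyond the scatter) and also a 27-fold lower number from compound 1 to compound 4 (1.42 log units; beyond the scatter). Group size alone does not set the direction, since compound 3 and compound 4 both carry a larger group than the methyl of compound 1, yet their numbers lie on opposite sides of the number for compound 1. Nothing measured here accounts for the gain seen with compound 4.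

The exchange from compound 3 to compound 4 brings in the six-membered ring and removes the amide hydrogen in a single step, so the contribution of each stays unresolved, and a cyclohexyl group or a piperidin-4-yl group with a free amine on the same carbonyl carbon would help to separate them from the terminal acetyl. Also open, going by these compounds, is whether the stereocentre at the saturated ring carbon, which separates compound 1 from compound 2 by only a 1.2-fold higher number from compound 1 to compound 2 (0.09 log units; within the scatter), stays as unimportant with 1-acetylpiperidin-4-yl in place.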